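Cyclopropyl Ring Replaces Propyl Chain on the Amide

The compounds below may be only part of what the source reports. "The series", "measured", "known", "first", "only" and "open" are said of these compounds alone.

Three amides of the shared core have been measured in an assay on SH-EP1 cells for agonist activity at Neuronal acetylcholine receptor; alpha4/beta2 (Homo sapiens), read by FLIPR and calcium flux; a lower number here means that less compound is needed, a higher number that more compound is needed for the effect. Compound 1 `CC(=O)N1CC2CC(C1)N2` gives 5100 nM, compound 2 `CCCC(=O)N1CC2CC(C1)N2` gives 580 nM, and compound 3 `O=C(C1CC=CC1)N1CC2CC(C1)N2` gives 6600 nM. Compound 2 thus stands lowest of the three, with compound 1 nearest and compound 3 furthest from it. Going by the values given here, the one step between compounds differing in a single place is an 8.8-fold lower number from compound 1 to compound 2 (0.94 log units; beyond the scatter), so lengthening the chain on the carbonyl carbon brought a clear gain.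

Compound 4 `O=C([C@@H]1C[C@H]1F)N1CC2CC(C1)N2` is not yet measured. It differs from compound 2 by 2-fluorocyclopropyl in place of propyl on a carbonyl carbon. Among the compounds with values here, no measured step covers this change directly: compound 3 carries a larger ring on the same carbonyl carbon and is weaker than compound 2, while the step from compound 1 to compound 2 shows only that more carbon at that position helped. A three-membered ring with fluorine keeps roughly the bulk of the propyl of compound 2 but is not the same group, so the expectation is a modest loss. Compound 4 is therefore expected to give about 1500 nM, within 300 nM to 7000 nM, which would mean an estimated step of a 2.6-fold higher number from compound 2 to compound 4 (0.41 log units; beyond the scatter).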

Compound 4, half-maximal effective concentration: 120 nM
For compound 4 the middle estimate is 13-fold (1.10 log units) above the measured one; measured number outside the range, below it.
By their numbers in this assay, from the lowest: compound 4; then compound 2; then compounds 1 and 3 (each within the scatter of the next).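

In this assay, the place on the carbonyl carbon proves to accept more than a straight chain: 2-fluorocyclopropyl in place of propyl gives a 4.8-fold lower number from compound 2 to compound 4 (0.68 log units; beyond the scatter) and so goes beyond the best compound of the earlier set, while the same group in place of methyl gives a 43-fold lower number from compound 1 to compound 4 (1.63 log units; beyond the scatter) as the largest step seen here. A ring at this place does not by itself settle the outcome, for compound 3 with its larger ring gives 6600 nM whereas compound 4 gives 120 nM in the same assay. Nothing available accounts for this gain.

Going by these compounds, what the three-membered ring and the fluorine each contribute remains open, as does the part played by the 2 defined stereocentres, and a plain cyclopropyl and the opposite stereoisomer of 2-fluorocyclopropyl on the same carbonyl carbon would address these questions. Going by these compounds alone, it is also open whether a longer chain such as butyl would extend the step seen on going from methyl to propyl, or whether 2,2-difluorocyclopropyl would go further than the single fluorine of compound 4.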